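The source may hold more compounds than are shown below. What is called first, only, known or untested is meant among the compounds shown, and "the series" means these compounds.

Measured so far:
compound 1 `CCOc1cc(C(C)(C)C)ccc1C/N=C(\S)NCc1ccc(NS(C)(=O)=O)cc1`, a functional assay for inhibition of Vanilloid receptor (Rattus norvegicus); on this read-out lower numbers stand for stronger inhibition and higher numbers for weaker inhibition: 1100 nM
compound 2 `CC(C)(C)C(=O)Oc1cc(C(C)(C)C)ccc1C/N=C(\S)NCc1ccc(NS(C)(=O)=O)cc1`, this assay: 220 nM

Compound 2 stands lowest of the two numbers; its nearest neighbour is compound 1, reached by a 5.0-fold lower number from compound 1 to compound 2 (0.70 log units; beyond the scatter). Compound 3 `CC(=O)OCc1cc(C(C)(C)C)ccc1C/N=C(\S)NCc1ccc(NS(C)(=O)=O)cc1` carries acetoxymethyl in place of ((tert-butyl)carbonyl)oxy on an aromatic carbon. Among the compounds with values here, only that one step bears on it, and it concerns the ester being present at all, not an acetoxymethyl in place of the ester oxygen; no measured pair covers that. The expectation for compound 3 in this assay is a small rise in number, probably within the scatter, estimated at 400 nM (range 130 nM to 1300 nM), meaning an expected step of a 1.8-fold higher number from compound 2 to compound 3 (0.26 log units; within the scatter).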

Compound 3, half-maximal inhibitory concentration: 580 nM
For compound 3 the middle estimate is 1.5-fold (0.16 log units) below the measured one; low and high end bracket the measured number.
By their numbers in this assay, from the lowest: compound 2; then compounds 3 and 1 (each within the scatter of the next).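

At this aromatic carbon, acetoxymethyl in place of ((tert-butyl)carbonyl)oxy gives a 2.6-fold higher number from compound 2 to compound 3 (0.42 log units; beyond the scatter) in this assay, so the presence of an ester group alone does not reproduce the lower number of compound 2. Acetoxymethyl in place of ethoxy gives a 1.9-fold lower number from compound 1 to compound 3 (0.28 log units; within the scatter), leaving these two compounds unseparated. Nothing on hand accounts for the difference between the groups.

Still open, on these data alone, is whether the tert-butyl part of the ester matters, which an acetoxy group on the same aromatic carbon would test. Also open, as far as these compounds go, is how a free hydroxyl or an amine there would read.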